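The source may hold more compounds than are shown below. What is called first, only, known or untested is meant among the compounds shown, and "the series" means these compounds.

Of the compounds shown here, three built on one shared core have been measured in a functional assay on L1210 cells (Mus musculus) for antiproliferative activity, read by MTT assay, with a stated time of 2 days; a higher number here means a weaker inhibitor, a lower number a stronger inhibitor. Compound 1 `CCCCCCCCC#Cc1cn(C/C=C\CN2C(=O)c3ccccc3C2=O)c(=O)[nH]c1=O` gives 45000 nM, compound 2 `CCCCc1ccc(C#Cc2cn(C/C=C\CN3C(=O)c4ccccc4C3=O)c(=O)[nH]c2=O)cc1` gives 31000 nM, and compound 3 `O=C1c2ccccc2C(=O)N1C/C=C\Cn1cc(C#CCCc2ccccc2)c(=O)[nH]c1=O` gives 143000 nM, the highest of the three numbers; the steps of a 3.2-fold higher number from compound 1 to compound 3 (0.50 log units; beyond the scatter) and a 4.6-fold higher number from compound 2 to compound 3 (0.66 log units; beyond the scatter) both lie beyond the scatter, whereas a 1.5-fold lower number from compound 1 to compound 2 (0.16 log units; within the scatter) does not. Compound 4 `Cc1ccc(C#Cc2cn(C/C=C\CN3C(=O)c4ccccc4C3=O)c(=O)[nH]c2=O)cc1` differs from compound 3 by 4-methylphenyl in place of phenethyl on a triple-bonded carbon. The step of a 4.6-fold higher number from compound 2 to compound 3 (0.66 log units; beyond the scatter) bears most directly on this change, since it ran the other way by a modest amount when a ring sitting on the triple-bonded carbon was exchanged for phenethyl. The expected step is therefore a 4.1-fold lower number from compound 3 to compound 4 (0.61 log units; beyond the scatter) in this assay. The estimate for compound 4 is 35000 nM, with a range from 15000 nM to 85000 nM.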

Compound 4, half-maximal inhibitory concentration: 245000 nM
Compound 4: middle estimate off by 7.0-fold (0.85 log units), on the low side, and the stated range ends below it.
By their numbers in this assay, from the lowest: compounds 2 and 1 (each within the scatter of the next); then compounds 3 and 4 (each within the scatter of the next).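

In this assay, a ring sitting directly on the triple-bonded carbon does not by itself lower the number, since 4-methylphenyl and phenethyl cannot be told apart, with a 1.7-fold higher number from compound 3 to compound 4 (0.23 log units; within the scatter) as the step. What counts more is the chain on that ring: cutting 4-butylphenyl back to 4-methylphenyl gives a 7.9-fold higher number from compound 2 to compound 4 (0.90 log units; beyond the scatter) and a clear loss. Octyl also outperforms 4-methylphenyl, with a 5.4-fold higher number from compound 1 to compound 4 (0.74 log units; beyond the scatter) as the step.

On these data alone, whether a longer chain or an amine on the ring would lower the number further stays open. No measurement shown explains why the chain matters.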